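Will compound 3 stay at the limit too?

A few compounds are considered here, and "the series" means these few. Any claim that something is new, unique, unknown or untested is made for them only; others in the source may bear on it.

In an ADME assay on HEK293 cells (Homo sapiens) for cytotoxicity, read by CellTiter-Glo and resazurin assay, with a stated time of 72 h (a lower number here means that less compound is needed, a higher number that more compound is needed for the effect), compound 2 `CC(C)N(Cc1cccc(OCCCCCC(=O)O)c1)C(=O)c1ccc(-c2cccc(C(F)(F)F)c2)cc1` gives > 26000 nM as its reading, and that is a limit, not a number. Compound 1 `CC(C)N(Cc1cccc(OCCCCCC(=O)O)c1)C(=O)c1ccc(-c2cccc(O)c2)cc1` gives > 26000 nM as its reading, also a limit. The evidence so far is the limit of > 26000 nM in this assay, at which 2 of the 2 values shown sit, and nothing more. Compound 3 `CC(C)N(Cc1cccc(OCCCCCC(=O)O)c1)C(=O)c1ccc(-c2ccc(Cl)c(Cl)c2)cc1` brings one change: 3,4-dichlorophenyl in place of 3-(trifluoromethyl)phenyl on an aromatic carbon. Among the measured compounds shown here, the only measured step, a step that the two limits leave unreadable from compound 1 to compound 2, has no size to carry over. No clear move is therefore expected in this assay, and the estimated step is a step that the limit leaves unreadable from compound 2 to compound 3 in size. For compound 3 the expected value is 30000 nM within an estimated range of 15000 nM to 50000 nM and may well be a limit again.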

Compound 3, half-maximal effective concentration: > 26000 nM
Compound 3: only a limit was reported; the forecaster's own chance of this, stated with the estimate: 80%; the middle value is on the limit's open side.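

Among the compounds shown here, compound 1, compound 2 and compound 3 all read as a limit rather than a number, and no step among them can be read. They leave open whether any compound of this kind reaches a measurable value in this assay.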